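Replacing the Hydrazone-Type Arm of Compound 1 with 2-Hydroxypropyl

The compounds below may be only part of what the source reports. "The series", "measured", "known", "first", "only" and "open" are said of these compounds alone.

Three compounds have been measured so far:
compound 1, `CN/N=C/c1ccc2ccc(=O)oc2c1`, 22.6%
compound 2, `O=c1ccc2ccc(/C=N/Nc3ccccc3)cc2o1`, 31.4%
compound 3, `O=c1ccc2ccc(/C=N/N=C/c3ccc4ccc(=O)oc4c3)cc2o1`, 9.4%

In a functional assay for inhibition of serine protease 1 (Homo sapiens), tested at 0.1 mM (a lower number here means a weaker effect, a higher number a stronger effect of the compound at the concentration tested), compound 1 gives 22.6%, which places it second highest of the three numbers. Its nearest neighbour is compound 2, a number higher but within the scatter; its furthest is compound 3 with 9.4%, a number lower and beyond the scatter.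

Compound 4, `CC(O)Cc1ccc2ccc(=O)oc2c1`, is not yet measured. It differs from compound 1 in one place: a group of 4 heavy atoms (3 carbon, 1 oxygen; no ring) in place of a group of 4 heavy atoms (2 carbon, 2 nitrogen; no ring), on an aromatic carbon. Among the measured compounds shown here, the only measured step that touches the same position is a number 8.8 percentage points higher from compound 1 to compound 2 (within the scatter), where one substituent on the amine nitrogen was exchanged for another while the rest of the group stayed. That step lay within the scatter. For the measured compounds named here, no measured step removes the whole group or introduces an oxygen-bearing chain, so nothing measured bears directly on the present change.

On that basis, a step of no clear size beyond the scatter is expected: a number 4.6 percentage points lower from compound 1 to compound 4 (within the scatter), with the risk that the number ends somewhat lower. Compound 4 is estimated at 18%, within a range from 5% to 32%.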

Compound 4, a percentage reported as inhibition, at one concentration (the size of the read-out at that concentration, not a potency): 29.3%
Compound 4: middle estimate off by 11.3 percentage points, on the low side; the range from low to high includes it.
By their numbers in this assay, from the lowest: compound 3; then compounds 1, 4 and 2 (each within the scatter of the next).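

In this assay, replacing the whole arm of compound 1 with 2-hydroxypropyl gives a number 6.7 percentage points higher from compound 1 to compound 4 (within the scatter). Among the compounds shown here, the only earlier step at this position exchanged a substituent on the amine nitrogen and left the rest of the arm in place, whereas this change removes both nitrogens and the double bond outside the aromatic rings, and the read-out still stays within the scatter. For this pair, then, the position on the aromatic carbon accepts a nitrogen-free chain carrying a hydroxyl group without a change that can be told from the scatter, and no measurement at hand accounts for this result.

The compounds shown do not tell whether the hydroxyl group of the 2-hydroxypropyl chain has any part in this read-out, a question that a plain propyl chain at the same aromatic carbon would address directly. They also leave open how the read-out responds to an amine, a carboxylic acid or a longer chain at this position, and whether any such group would move it beyond the scatter.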